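Cyclopropyl to methyl on the thiazole: cytotoxicity notes

The compounds below may be only part of what the source reports. "The series", "measured", "known", "first", "only" and "open" are said of these compounds alone.

Measured compounds:
compound 1 `COc1ccc2c(O[C@H]3C[C@H]4C(=O)N(C)CCCC/C=C/[C@@H]5C[C@@]5(C(=O)NS(=O)(=O)C5CC5)NC(=O)N4C3)cc(-c3nc(C4CC4)cs3)nc2c1Cl`, 31300 nM
compound 2 `COc1ccc2c(O[C@H]3C[C@H]4C(=O)N(C)CCCC/C=C/[C@@H]5C[C@@]5(C(=O)NS(=O)(=O)C5(C)CC5)NC(=O)N4C3)cc(-n3cc(C(C)C)cn3)nc2c1C`, 9610 nM

In an ADME assay on Huh-7 cells (Homo sapiens) for cytotoxicity, read by colorimetric assay (on this read-out lower numbers stand for higher toxicity in this test and higher numbers for lower toxicity in this test), compound 1 gives 31300 nM, the highest of the two numbers; compound 2 gives 9610 nM, a lower number beyond the scatter. Among the measured compounds shown here, no pair differing in one place has been measured, so no step size is known. Compound 3 `COc1ccc2c(O[C@H]3C[C@H]4C(=O)N(C)CCCC/C=C/[C@@H]5C[C@@]5(C(=O)NS(=O)(=O)C5CC5)NC(=O)N4C3)cc(-c3nc(C)cs3)nc2c1Cl` differs from compound 1 by methyl in place of cyclopropyl on an aromatic carbon. With nothing in the series to anchor this change, the step of a 1.0-fold lower number from compound 1 to compound 3 (0.02 log units; within the scatter) is expected to stay within the scatter, in no particular direction. Compound 3 is therefore estimated at 30000 nM, range 12000 nM to 75000 nM.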

Compound 3, half-maximal cytotoxic concentration: 75000 nM
The estimate for compound 3 lay 2.5-fold (0.40 log units) below the measured number; measured number inside the range.
By their numbers in this assay, from the lowest: compound 2; then compound 1; then compound 3.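

In this assay, a 2.4-fold higher number from compound 1 to compound 3 (0.38 log units; beyond the scatter) goes with replacing 4-cyclopropyl-1,3-thiazol-2-yl by 4-methyl-1,3-thiazol-2-yl. Among the compounds shown here, this is the first single-place step, and it shows that this aromatic carbon can move the read-out beyond the scatter, with methyl giving the higher number. Nothing measured here accounts for the step. Open, going by these compounds, is where an ethyl, an isopropyl or an amine on this carbon would fall relative to methyl and cyclopropyl, and whether the step carries over to other cores.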